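The source may report more compounds than this note shows. Statements on the series, on what has been measured and on what is new or still open speak of the compounds shown alone.

Measured in an ADME assay on microsomes from liver (Rattus norvegicus) for metabolic stability, read by LC-MS, tested at 1 uM (a lower number here means that the compound disappears faster, a higher number that the compound lasts longer), so far:
- compound 1 `Nc1ncnc2c1c(Oc1cccc(Cl)c1)nn2CC1CCNC(=O)C1` gives > 1 h as a limit
- compound 2 `Nc1ncnc2c1c(Nc1cccc(Cl)c1)nn2CC1CCNCC1` gives 0.333 h as a number
- compound 3 `Cc1cccc(Sc2nn(CC3CCNCC3)c3ncnc(N)c23)c1` gives 0.433 h as a number

Going by the values given here, the entry for compound 1 is a limit and not a number: it stands as the limit of > 1 h in this assay, at which 1 of the 3 values shown sits, and yields no size of step.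

Of the two actual numbers, compound 3 at 0.433 h lies within the scatter of compound 2 at 0.333 h and the two cannot be ranked.

The change from compound 3 to compound 4 `Nc1ncnc2c1c(Oc1cccc(Cl)c1)nn2CC1CCNCC1` puts 3-chlorophenoxy in place of (3-methylphenyl)sulfanyl on an aromatic carbon, with 3-chlorophenoxy in place of (3-methylphenyl)sulfanyl on an aromatic carbon as the counted difference.

Among the compounds with values here, the one measured step that bears on this is a 1.3-fold higher number from compound 2 to compound 3 (0.11 log units; within the scatter) at the same aromatic carbon, where (3-methylphenyl)sulfanyl replaced (3-chlorophenyl)amino. A single step within the scatter is thin support, but with compound 3 at 0.433 h as the anchor, no step beyond the scatter is expected in this assay for this change.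

The expected step is a 1.0-fold higher number from compound 3 to compound 4 (0.02 log units; within the scatter) on this reasoning.

Compound 4 is estimated at 0.45 h with a range from 0.22 h to 0.95 h as the expected bounds.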

Compound 4, half-life: > 1 h
Compound 4 gave a limit, no number; the forecaster's own chance of this, stated with the estimate: 15%; at least 2.2-fold (0.34 log units) between middle value and limit.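

With the (piperidin-4-yl)methyl group unchanged in this assay, 3-chlorophenoxy at this aromatic carbon gives an at least 2.3-fold higher number from compound 3 to compound 4 (0.36 log units; beyond the scatter) against (3-methylphenyl)sulfanyl and an at least 3.0-fold higher number from compound 2 to compound 4 (0.47 log units; beyond the scatter) against (3-chlorophenyl)amino. The only earlier step at this carbon, a 1.3-fold higher number from compound 2 to compound 3 (0.11 log units; within the scatter), showed no separation, so this is the first evidence shown that a change at this position can move the half-life beyond the scatter. The comparison of compound 2 with compound 4 is the cleaner one, since the 3-chlorophenyl ring stays and the link changes from amino to oxygen, whereas the link and the ring substituent change together between compound 3 and compound 4.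

Going by these compounds, the step between compound 1 and compound 4 cannot be read, and the full size of the two steps into compound 4 stays open: the limit of > 1 h in this assay, at which 2 of the 4 values shown sit. Whether a (3-chlorophenyl)sulfanyl group, which would separate the effect of the sulfur link from that of the ring substituent, or a 3-chlorobenzyl group with a carbon link would sit with 3-chlorophenoxy or with the other two groups also stays open.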